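A few compounds are considered here, and "the series" means these few. Any claim that something is new, unique, unknown or untested is made for them only; others in the source may bear on it.

Compound 1 `Cc1cc(O)c(C2=NN(c3ccc(S(N)(=O)=O)cc3)C(c3ccccc3O)C2)cc1Cl` gives 4740 nM in a functional assay on MOLT-4 cells (Homo sapiens) for antiproliferative activity, with a stated time of 48 h; on this read-out lower numbers stand for stronger inhibition of growth and higher numbers for weaker inhibition of growth.
Compound 2 `Cc1cc(O)c(C2=NN(c3ccc(S(N)(=O)=O)cc3)C(/C=C/c3ccccc3)C2)cc1Cl` gives 17700 nM in this assay.
Compound 3 `COc1ccc(C2CC(c3cc(Cl)c(C)cc3O)=NN2c2ccc(S(N)(=O)=O)cc2)cc1OC` gives 5290 nM in this assay.

Compound 1 stands together with compound 3, the two numbers lying within the usual scatter of each other, while compound 2 sits beyond it. Compound 4 `COc1ccc(C2CC(c3cc(Cl)c(C)cc3O)=NN2c2ccc(S(N)(=O)=O)cc2)c(OC)c1OC` arises from compound 1 by 2,3,4-trimethoxyphenyl in place of 2-hydroxyphenyl on a saturated ring carbon. The step that bears most directly on this change is a 1.1-fold higher number from compound 1 to compound 3 (0.05 log units; within the scatter), a methoxy-bearing ring replacing the hydroxyphenyl without a shift beyond the scatter. The step of a 3.7-fold higher number from compound 1 to compound 2 (0.57 log units; beyond the scatter) shows that a different replacement at the same carbon does cost, but it is a less similar change. No step beyond the scatter is therefore expected, and compound 4 is estimated at 6000 nM, between 2500 nM and 15000 nM, a step of a 1.3-fold higher number from compound 1 to compound 4 (0.10 log units; within the scatter).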

Compound 4, concentration for 50% growth inhibition: 4460 nM
The estimate for compound 4 lay 1.3-fold (0.13 log units) above the measured number; the range from low to high includes it.
By their numbers in this assay, from the lowest: compounds 4, 1 and 3 (each within the scatter of the next); then compound 2.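

The 2,3,4-trimethoxyphenyl group carries no hydrogen-bond donor, yet in this assay the step of a 1.1-fold lower number from compound 1 to compound 4 (0.03 log units; within the scatter) shows that a hydroxyl on this aryl ring is not required to hold the number at this carbon. A third methoxy on the ring also leaves the reading within the scatter, with a 1.2-fold lower number from compound 3 to compound 4 (0.07 log units; within the scatter) as the step. Only 2-phenylethenyl stands apart, as a 4.0-fold lower number from compound 2 to compound 4 (0.60 log units; beyond the scatter) shows again.

No measurement given here explains why these aryl groups read alike. From the compounds shown here alone, whether an amine or a carboxylic acid on this aryl ring would do the same remains open.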